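Taking Away the Ring Methyl: Expected Effect on Cytotoxicity

The compounds below may be only part of what the source reports. "The series", "measured", "known", "first", "only" and "open" are said of these compounds alone.

Compound 1 `CS(=O)(=O)c1ccc2nc(NC(=O)CCCCC(=O)NO)sc2c1`: in a functional assay on SW-620 cells (Homo sapiens) for cytotoxicity (on this read-out lower numbers stand for stronger inhibition and higher numbers for weaker inhibition), compound 1 gives only the assay limit > 30 ug/mL.
Compound 2 `Cc1ccc2nc(NC(=O)CCCCCCC(=O)NO)sc2c1`: in this assay compound 2 gives 0.56 ug/mL.
Compound 3 `Cc1ccc2nc(NC(=O)CCCCC(=O)NO)sc2c1`: in this assay compound 3 gives 4.69 ug/mL.

Of the two numbers, compound 3 stands highest; its nearest neighbour is compound 2, and the chain change between them gave an 8.4-fold higher number from compound 2 to compound 3 (0.92 log units; beyond the scatter). The step to compound 4 `O=C(CCCCC(=O)Nc1nc2ccccc2s1)NO` is hydrogen in place of methyl on an aromatic carbon. The measured step that most resembles it sits on the same aromatic carbon: an at least 6.3-fold lower number from compound 1 to compound 3 (0.80 log units; beyond the scatter), which shows that the group at this position matters. Removing the methyl is expected to weaken cytotoxicity modestly, near the edge of the scatter, a 1.7-fold higher number from compound 3 to compound 4 (0.23 log units; within the scatter). Compound 4 is therefore estimated at 8 ug/mL, within 3 ug/mL to 18 ug/mL.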

Compound 4, half-maximal inhibitory concentration: 7.85 ug/mL
Compound 4: the middle estimate sits 1.0-fold (0.01 log units) above what was measured; the range from low to high includes it.
By their numbers in this assay, from the lowest: compound 2; then compounds 3 and 4 (each within the scatter of the next). At a limit, above all of these: compound 1.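

Hydrogen and methyl on this aromatic carbon cannot be told apart in cytotoxicity (a 1.7-fold higher number from compound 3 to compound 4 (0.22 log units; within the scatter)), so the methyl is not needed here. Methylsulfonyl stands apart from both, since the bare core also lies beyond the scatter from it (an at least 3.8-fold lower number from compound 1 to compound 4 (0.58 log units; beyond the scatter)). Compound 1 sits at a limit of the assay, so that step gives only a minimum size: the limit of > 30 ug/mL in this assay, at which 1 of the 4 values shown sits.

As far as these compounds go, whether an amine or a carboxylic acid on this carbon would behave like hydrogen or like methylsulfonyl stays open. So does whether a longer chain would lower the number for compound 4, as it does between compound 3 and compound 2.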